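The compounds below may be only part of what the source reports. "The series", "measured", "known", "first", "only" and "open" are said of these compounds alone.

For the measured compounds named here, compound 1 `Cn1c(-c2ccc(NC(=O)CSc3nc4ccccc4s3)cc2)nc(-c2ccccc2)c1-c1ccccc1` stands highest of the two compounds measured so far: in a functional assay on HT-29 cells (Homo sapiens) for cytotoxicity, read by MTT assay, with a stated time of 24 h, tested at 32 ug/mL (on this read-out lower numbers stand for a weaker effect and higher numbers for a stronger effect at the one concentration tested), compound 1 gives 66%, whereas compound 2 `CN(C)/C=C/N1CCN(CC(=O)Nc2ccc(-c3nc(-c4ccccc4)c(-c4ccccc4)n3C)cc2)CC1` gives 29.8%. Compound 3 `Cn1c(-c2ccc(NC(=O)CN3CCN(c4ccccc4)CC3)cc2)nc(-c2ccccc2)c1-c1ccccc1` differs from compound 1 in one place: 4-phenylpiperazin-1-yl in place of (1,3-benzothiazol-2-yl)sulfanyl on a saturated chain carbon bound to a carbonyl carbon. Going by the values given here, the only measured step that bears on this change is a number 36.2 percentage points lower from compound 1 to compound 2 (beyond the scatter), where the (1,3-benzothiazol-2-yl)sulfanyl group on the saturated chain carbon bound to the carbonyl carbon was likewise replaced. A drop beyond the scatter is therefore expected for compound 3. Compound 3 is estimated at 40% in this assay, with a range of 22% to 60%, which is expected to mean a number 26 percentage points lower from compound 1 to compound 3 (beyond the scatter).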

Compound 3, a percentage reported as activity, at one concentration (the size of the read-out at that concentration, not a potency): 60.5%
The estimate for compound 3 lay 20.5 percentage points below the measured number, outside the stated range (above it).
By their numbers in this assay, from the lowest: compound 2; then compounds 3 and 1 (each within the scatter of the next).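

In this assay, the (1,3-benzothiazol-2-yl)sulfanyl group on the saturated chain carbon bound to a carbonyl carbon can give way to 4-phenylpiperazin-1-yl with only a number 5.5 percentage points lower from compound 1 to compound 3 (within the scatter). The earlier drop therefore does not follow from that replacement as such, nor from the piperazine ring alone: on the amine nitrogen in the ring, phenyl in place of 2-(dimethylamino)ethenyl gives a number 30.7 percentage points higher from compound 2 to compound 3 (beyond the scatter). Nothing available explains these steps. Still open, from the compounds shown here alone, is how a methyl or an acetyl on that ring nitrogen would read, and whether a morpholine ring could stand in place of the piperazine.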